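Hydroxypropyl chain isomers on a bromoadenine-type core

The source may hold more compounds than are shown below. What is called first, only, known or untested is meant among the compounds shown, and "the series" means these compounds.

Measured so far:
- compound 1 `CC(O)Cn1cnc2ncnc(N)c21`: > 30000 nM in a functional assay on CHO cells for antagonist activity at adenosine receptor A2b (Homo sapiens); on this read-out lower numbers stand for stronger inhibition and higher numbers for weaker inhibition
- compound 2 `Nc1ncnc2c1nc(Br)n2CCCO`: 5100 nM in this assay

Among the compounds with values here, compound 2 holds the only finite number in this assay; compound 1 reports a limit, not a number (the limit of > 30000 nM in this assay, at which 1 of the 2 values shown sits). Compound 2 stands at 5100 nM in this assay, and compound 1 at > 30000 nM, a limit of the assay. Compound 3 `CC(O)Cn1c(Br)nc2c(N)ncnc21` has the same atoms as compound 2 but joined differently: 1-hydroxyethyl in place of 2-hydroxyethyl on a saturated chain carbon bound to an aromatic nitrogen. Within the data shown here, no step between measured compounds has been computed for this change, so its size rests on expectation only. The isomeric shift is expected to cost little, with a modest loss in this assay; the estimated step of a 1.8-fold higher number from compound 2 to compound 3 (0.25 log units; within the scatter) lies close to the scatter, tilted toward weaker inhibition. Compound 3 is therefore expected at 9000 nM in this assay, within a range from 2500 nM to 30000 nM.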

Compound 3, inhibition constant: 640 nM
Beside the measured number, compound 3's estimate is 14-fold (1.15 log units) above it; measured number below the stated range.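

In this assay, replacing 3-hydroxypropyl with 2-hydroxypropyl gives an 8.0-fold lower number from compound 2 to compound 3 (0.90 log units; beyond the scatter), so the read-out separates these two chains clearly even though the atoms are the same. Compound 1, which has the 2-hydroxypropyl chain but no bromo group on the shared core, reports a limit, not a number: the limit of > 30000 nM in this assay, at which 1 of the 3 values shown sits. The compounds shown offer no measured property that accounts for the isomer step.

Steps involving compound 1 cannot be read, so the size of the bromo group's contribution remains open. Also open, going by these compounds, is whether a longer chain, or an amine or a carboxylic acid in place of the hydroxyl, would hold, improve or lose the number seen for compound 3.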